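Lengthening the Ester Chain of Compound 3

The source may hold more compounds than are shown below. What is called first, only, known or untested is meant among the compounds shown, and "the series" means these compounds.

Compound 3 `CCCCCCCCCCOC(=O)CC(=O)Nc1c(C(C)C)cccc1C(C)C` was tested in an assay on microsomes from intestine for inhibition of acyl-CoA:cholesterol acyltransferase (Oryctolagus cuniculus) (a lower number here means a stronger inhibitor, a higher number a weaker inhibitor), where compound 3 gives 53 nM, the higher of the two numbers seen; compound 1 `CC(C)c1cccc(C(C)C)c1NC(=O)CC(=O)OC(c1ccccc1)c1ccccc1` gives 38 nM, a gap that lies within the scatter. Compound 2 `CC(C)c1cccc(C(C)C)c1NC(=O)CC(=O)OC(c1ccccc1)c1ccccn1` reaches only a limit of the assay, > 5000 nM. Among the compounds with values here, the single measured step, an at least 130-fold higher number from compound 1 to compound 2 (2.11 log units; beyond the scatter), is large, but it exchanges an aromatic group and has nothing to say about the chain. Compound 4 `CCCCCCCCCCCCCCCCOC(=O)CC(=O)Nc1c(C(C)C)cccc1C(C)C` differs from compound 3 by hexyl in place of hydrogen on a saturated chain carbon, ten or more bonds along the chain from an oxygen next to a carbonyl group. Within the data shown here, no measured step bears on this change, so compound 4 is expected to show a step of a 1.1-fold higher number from compound 3 to compound 4 (0.05 log units; within the scatter), within the scatter. Compound 4 is estimated at 60 nM, with a range from 25 nM to 150 nM.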

Compound 4, half-maximal inhibitory concentration: 35 nM
For compound 4 the middle estimate is 1.7-fold (0.23 log units) above the measured one; the range from low to high includes it.
By their numbers in this assay, from the lowest: compounds 4, 1 and 3 (each within the scatter of the next). At a limit, above all of these: compound 2.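

In this assay hexyl in place of hydrogen on a saturated chain carbon, ten or more bonds along the chain from an oxygen next to a carbonyl group, gives a 1.5-fold lower number from compound 3 to compound 4 (0.18 log units; within the scatter) and so leaves the two compounds indistinguishable. Within the data shown here, this is the first measured step on the chain itself, and it shows that this extension is tolerated, whereas the earlier step exchanged an aromatic group. Nothing at hand gives a reason for this result. Going by these compounds, what a much shorter chain would do remains open, as does the effect of an amine or a carboxylic acid on the chain.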